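This account rests on a few compounds, and the source may have more. Where it says the series, first, only, none or still open, it means among the compounds named here.

In an ADME assay on cells (Hepatocyte, Mus musculus) for cytotoxicity, read by MTT assay, with a stated time of 24 h (on this read-out lower numbers stand for higher toxicity in this test and higher numbers for lower toxicity in this test), compound 1 (`Cc1ccc(-c2nn(-c3ccccc3)cc2-c2nc3ccccc3n2S(=O)(=O)c2ccccc2)cc1`) gives 189000 nM while compound 2 (`Cc1ccc(-c2nn(-c3ccccc3)cc2-c2nc3ccccc3n2S(=O)(=O)c2ccc(C)cc2)cc1`) gives 102000 nM and compound 3 (`COc1ccc(S(=O)(=O)n2c(-c3cn(-c4ccccc4)nc3-c3ccc(F)cc3)nc3ccccc32)cc1`) gives 105000 nM in the same test. These three numbers lie within the usual scatter of one another, so compound 3 stands level with both. Compound 4 (`O=S(=O)(c1ccc(Cl)cc1)n1c(-c2cn(-c3ccccc3)nc2-c2ccc(F)cc2)nc2ccccc21`) carries chloro in place of methoxy on an aromatic carbon, para to a large group (chloro in place of methoxy on an aromatic carbon). Going by the values given here, no measured step makes this exact swap. Among the compounds with values here, the only step available, a 1.9-fold lower number from compound 1 to compound 2 (0.27 log units; within the scatter) for methyl in place of hydrogen on an aromatic carbon, lies within the scatter. In this assay the expected change (a 1.1-fold lower number from compound 3 to compound 4 (0.02 log units; within the scatter)) is therefore estimated to stay within the scatter, with no favoured direction. Compound 4 is expected at 100000 nM with an estimated range from 50000 nM to 200000 nM for repeated measurements.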

Compound 4, half-maximal cytotoxic concentration: 231000 nM
Compound 4: middle estimate off by 2.3-fold (0.36 log units), on the low side; measured number above the stated range.
By their numbers in this assay, from the lowest: compounds 2, 3, 1 and 4 (each within the scatter of the next, the first and the last beyond it).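

Chloro in place of methoxy on this aromatic carbon gives the first single-place step here that lies beyond the scatter (a 2.2-fold higher number from compound 3 to compound 4 (0.34 log units; beyond the scatter)), though the step is modest. In this assay a higher number stands for lower toxicity in this test, so this position can shift the read-out, and the shift runs towards lower toxicity. No measurement given here accounts for the change.

As far as these compounds go, what an amine or a carboxylic acid would do at this position remains open. So does whether the same swap gives a similar step with the rest of the molecule altered.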